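The compounds below may be only part of what the source reports. "The series", "measured", "known", "first", "only" and "open" are said of these compounds alone.

Compound 3 `CCCCCCNc1cc(-c2ccccc2)c(-c2ccccc2)nn1` gives 24000 nM in an assay on microsomes from liver for inhibition of sterol O-acyltransferase 1 (Rattus norvegicus) (a lower number here means a stronger inhibitor, a higher number a weaker inhibitor), the lowest of the three numbers: compound 1 `CCCCCCCCCn1nc(-c2ccccc2)c(-c2ccccc2)cc1=O` gives 85000 nM and compound 2 `O=c1cc(-c2ccccc2)c(-c2ccccc2)nn1C1CCCC1` gives 119000 nM, so compound 3 is the strongest inhibitor among them. Among the measured compounds shown here, the only measured step, a 1.4-fold higher number from compound 1 to compound 2 (0.15 log units; within the scatter), swaps one chain for a ring on an aromatic nitrogen and says little about the carbon position changed here. Compound 4 `CCCCCCCCOc1cc(-c2ccccc2)c(-c2ccccc2)nn1` differs from compound 3 by octyloxy in place of hexylamino on an aromatic carbon. For the measured compounds named here, no measured step replaces hexylamino with octyloxy, so the data offer no direct guide, and the one chain swap stayed within the scatter. Compound 4 is therefore expected to give about 30000 nM, within a range from 10000 nM to 90000 nM. The expected step, a 1.3-fold higher number from compound 3 to compound 4 (0.10 log units; within the scatter), is estimated to stay within the scatter.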

Compound 4, half-maximal inhibitory concentration: 104000 nM
Compound 4: middle estimate off by 3.5-fold (0.54 log units), on the low side; the whole stated range lies below it.
By their numbers in this assay, from the lowest: compound 3; then compounds 1, 4 and 2 (each within the scatter of the next).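

In this assay, among the compounds shown here, this aromatic carbon position is sensitive to the group it carries: octyloxy in place of hexylamino gives a 4.3-fold higher number from compound 3 to compound 4 (0.64 log units; beyond the scatter), whereas the only earlier step, on an aromatic nitrogen, stayed within the scatter. This swap changes two things at once, as hexylamino carries a hydrogen-bond donor and octyloxy carries none, while the chain also differs in length. No evidence at hand bears on the reason for this rise. Still open, on these data alone, is whether the linking atom or the chain length accounts for the step; octylamino or hexyloxy at this position would separate the two.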